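The compounds below may be only part of what the source reports. "The series", "measured", "known", "first", "only" and "open" are said of these compounds alone.

Measured compounds:
Compound 1, `O=C(Cc1ccccn1)N[C@H]1CCC[C@H](NC(=O)c2cccc(Cl)c2)C1`. In a functional assay on HEK293 cells for antagonist activity at metabotropic glutamate receptor 5 (Homo sapiens), read by FLIPR and calcium flux (a lower number here means a stronger inhibitor, a higher number a weaker inhibitor), compound 1 gives only a limit, > 10000 nM.
Compound 2, `O=C(N[C@H]1CCC[C@H](NC(=O)c2cccc(Cl)c2)C1)c1cccnc1`. In this assay compound 2 gives 612 nM.

Within the data shown here, compound 2 holds the only numeric value; compound 1 sits at a limit (the limit of > 10000 nM in this assay, at which 1 of the 2 values shown sits). Compound 3, `Cc1cccnc1C(=O)N[C@H]1CCC[C@H](NC(=O)c2cccc(Cl)c2)C1`, differs from compound 2 in one place: 3-methylpyridin-2-yl in place of pyridin-3-yl on a carbonyl carbon. Among the measured compounds shown here, the only measured step, an at least 16-fold lower number from compound 1 to compound 2 (1.21 log units; beyond the scatter), bears on it, as it also swaps the group on this carbonyl carbon. For compound 3 a modest weakening is expected in this assay, about a 2.5-fold higher number from compound 2 to compound 3 (0.39 log units; beyond the scatter), with wide uncertainty. Compound 3 is estimated at 1500 nM, between 300 nM and 10000 nM.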

Compound 3, half-maximal inhibitory concentration: 7840 nM
Compound 3: the middle estimate sits 5.2-fold (0.72 log units) below what was measured; the measured number falls inside the stated range.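

At this carbonyl carbon, a pyridinyl group attached directly does not by itself secure the gain seen with compound 2: in this assay, 3-methylpyridin-2-yl gives a 13-fold higher number from compound 2 to compound 3 (1.11 log units; beyond the scatter). Against the other weak compound the change gives an at least 1.2-fold lower number from compound 1 to compound 3 (0.10 log units; that floor lies within the scatter), so compound 3 cannot be ordered against compound 1. Compound 1 gives a limit, not a number: the limit of > 10000 nM in this assay, at which 1 of the 3 values shown sits.

Still open, from the compounds shown here alone, is whether the methyl or the shift from pyridin-3-yl to a pyridin-2-yl attachment carries the step, and how an unsubstituted pyridin-2-yl or a phenyl group would read on this carbonyl carbon.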